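A few compounds are considered here, and "the series" means these few. Any claim that something is new, unique, unknown or untested is made for them only; others in the source may bear on it.

Measured so far in a physicochemical assay, with a stated time of 30 min (on this read-out lower numbers stand for stronger inhibition and higher numbers for weaker inhibition), for the series:
compound 1 `CCc1ccc(NC(=O)C2Cc3cc(OC)c(OC)cc3C2=O)cc1` gives 76.2 ug/mL
compound 2 `COc1cc2c(cc1OC)C(=O)C(C(=O)Nc1ccc(F)cc1)C2` gives 55 ug/mL
compound 3 `CCOc1ccccc1NC(=O)C1Cc2cc(OC)c(OC)cc2C1=O` gives 63.7 ug/mL

The value of compound 3 lies within the scatter of both compound 1 and compound 2, so the three numbers do not separate in this assay and compound 3 offers a level baseline.

Still unmeasured is compound 4 `COc1cc2c(cc1OC)C(=O)C(C(=O)Nc1ccccc1F)C2` which carries fluoro in place of ethoxy on an aromatic carbon at a place ortho to a large group. Among the compounds with values here, one measured step bears on this change: a 1.4-fold lower number from compound 1 to compound 2 (0.14 log units; within the scatter) also brings in fluoro on an aromatic carbon, though there it replaces ethyl. Within the data shown here, no measured step removes ethoxy, so this support is indirect. That single step gives no reason to expect a shift beyond the scatter.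

The expected change is a 1.2-fold lower number from compound 3 to compound 4 (0.06 log units; within the scatter) and this estimate stays within the scatter. For compound 4 the estimate is 55 ug/mL with an expected range from 35 ug/mL to 85 ug/mL in this series.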

Compound 4, half-maximal inhibitory concentration: 75.7 ug/mL
The estimate for compound 4 lay 1.4-fold (0.14 log units) below the measured number; measured number inside the range.
By their numbers in this assay, from the lowest: compounds 2, 3, 4 and 1 (each within the scatter of the next).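

In this assay, fluoro in place of ethoxy on an aromatic carbon ortho to a large group leaves the number within the scatter, with a 1.2-fold higher number from compound 3 to compound 4 (0.07 log units; within the scatter). The other two steps on the amide-type nitrogen also stay within the scatter: 2-fluorophenyl in place of 4-fluorophenyl gives a 1.4-fold higher number from compound 2 to compound 4 (0.14 log units; within the scatter), and 2-fluorophenyl in place of 4-ethylphenyl gives a 1.0-fold lower number from compound 1 to compound 4 (0.00 log units; within the scatter), so the read-out separates neither these groups nor these placements of fluoro. Nothing available accounts for this lack of separation.

From the compounds shown here alone, whether an amine or a carboxylic acid on this aromatic carbon, or a longer chain in place of ethoxy, would give a step beyond the scatter remains open. With every step among these four compounds within the scatter, the substituents shown cannot yet be ranked.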